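An Amide Added to the Indane of Compound 1

The source may report more compounds than this note shows. Statements on the series, on what has been measured and on what is new or still open speak of the compounds shown alone.

Compound 1 `NS(=O)(=O)OC[C@@H]1C[C@@H](n2nnc3c(N[C@H]4CCc5ccccc54)ncnc32)C[C@@H]1O` gives 0.21 nM in an assay on a protein complex for inhibition of NEDD8 activating enzyme (Homo sapiens), read by HTRF, with a stated time of 2 h, in the presence of a further agent that is not named here (a higher number here means a weaker inhibitor, a lower number a stronger inhibitor), the lowest of the two numbers shown. Compound 2 `NS(=O)(=O)OC[C@@H]1C[C@@H](n2nnc3c(NCc4cccs4)ncnc32)C[C@@H]1O` gives 15.9 nM in this assay, a step of a 76-fold higher number from compound 1 to compound 2 (1.88 log units; beyond the scatter). Compound 3 `NS(=O)(=O)OC[C@@H]1C[C@@H](n2nnc3c(NC4CCCC4)ncnc32)C[C@@H]1O` reaches only a limit of the assay, > 10000 nM. Compound 4 `COCC(=O)N[C@@H]1Cc2ccccc2[C@H]1Nc1ncnc2c1nnn2[C@@H]1C[C@@H](COS(N)(=O)=O)[C@@H](O)C1` differs from compound 1 by ((methoxymethyl)carbonyl)amino in place of hydrogen on a saturated ring carbon. Within the data shown here, none of the measured steps bears directly on this change: each of them, a 76-fold higher number from compound 1 to compound 2 (1.88 log units; beyond the scatter), an at least 47000-fold higher number from compound 1 to compound 3 (4.67 log units; beyond the scatter) and an at least 620-fold higher number from compound 2 to compound 3 (2.79 log units; beyond the scatter), replaces the whole group on the aromatic-ring nitrogen, whereas compound 4 keeps that group and adds a substituent to it. The low number of compound 1 is therefore expected to be largely retained, with a modest step in this assay at most. Compound 4 is estimated at 0.6 nM (range 0.15 nM to 3 nM), a step of a 2.9-fold higher number from compound 1 to compound 4 (0.46 log units; beyond the scatter).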

Compound 4, half-maximal inhibitory concentration: > 10000 nM
Compound 4 was reported as a limit; the forecaster's own chance of this, stated with the estimate: 0%; at least 16000-fold (4.22 log units) between middle value and limit.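

Adding ((methoxymethyl)carbonyl)amino on a saturated ring carbon, next to the ring atom that bears a large group, brings an at least 47000-fold higher number from compound 1 to compound 4 (4.67 log units; beyond the scatter) in this assay. The earlier steps shown here all replaced the whole group on the aromatic-ring nitrogen, whereas this one shows that a substituent added to that group is enough to lose the low number of compound 1. On these data alone, the value of compound 4 is a limit of the assay and not a number, so the full size of the step remains unknown: the limit of > 10000 nM in this assay, at which 2 of the 4 values shown sit.

As far as these compounds go, whether a hydroxyl, a free amine or a simple acetamide on this carbon would keep the low number remains open. So does the effect of the opposite configuration at this carbon.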